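Notes on the ether change from compound 2 to compound 3

A few compounds are considered here, and "the series" means these few. Any claim that something is new, unique, unknown or untested is made for them only; others in the source may bear on it.

Measured compounds:
Compound 1, `FC(F)(F)Oc1ccc(Oc2ccnc(N3CCC(NC(=S)Nc4cccnc4)CC3)c2Cl)cc1`: in an assay on membranes from brain for binding affinity to Lysophosphatidylserine lipase ABHD12 (Mus musculus), read by fluorescence, with a stated time of 20 min (a lower number here means a stronger inhibitor, a higher number a weaker inhibitor), compound 1 gives 25 nM.
Compound 2, `FC(F)(F)Oc1ccc(Oc2ccnc(N3CCC(NC(=S)Nc4cccnc4)CC3)c2)cc1`: in this assay compound 2 gives 410 nM.

Among the compounds with values here, compound 2 holds the higher of the two numbers so far; the only measured step, a 16-fold higher number from compound 1 to compound 2 (1.21 log units; beyond the scatter), separates it from compound 1, which is the one comparison available.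

Compound 3, `S=C(Nc1cccnc1)NC1CCN(c2cc(OCc3ccccc3)ccn2)CC1`, is not yet measured. Relative to compound 2 the change is benzyl in place of 4-(trifluoromethoxy)phenyl on an oxygen on an aromatic ring. Within the data shown here, the single measured step concerns the chloro on an aromatic carbon and leaves the ether portion untouched, so no measured step bears on the change to compound 3. The data contain no comparison of an aryl group against a benzyl group on this oxygen, and the direction of the step cannot be read from the two measured compounds.

Among the measured compounds shown here, with no precedent, the expectation for compound 3 in this assay is set wide, and the estimated step is a 2.4-fold higher number from compound 2 to compound 3 (0.39 log units; beyond the scatter), with a weaker result treated as somewhat more probable than a stronger one. Compound 3 is therefore estimated at 1000 nM, in a range from 250 nM to 4000 nM.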

Compound 3, half-maximal inhibitory concentration: 2800 nM
Compound 3: middle estimate off by 2.8-fold (0.45 log units), on the low side; the measured number falls inside the stated range.
By their numbers in this assay, from the lowest: compound 1; then compound 2; then compound 3.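

In this assay, within the data shown here, the step on the oxygen is a 6.8-fold higher number from compound 2 to compound 3 (0.83 log units; beyond the scatter) and gives the first measured reading at this position, where the earlier step concerned only the chloro on an aromatic carbon. Benzyl in place of 4-(trifluoromethoxy)phenyl gives a weaker inhibitor here, so the group on this oxygen matters to the number and not only the chloro. The change is a single swap of whole groups, from 11 heavy atoms and 1 hydrogen-bond acceptor to 7 heavy atoms and 0 hydrogen-bond acceptors, and nothing measured here gives a reason for the loss.

The compounds shown leave open which part of the swap carries the step: a plain phenyl, a 4-(trifluoromethoxy)benzyl or a longer chain such as 2-phenylethyl on the same oxygen would begin to separate the aryl-to-benzyl change from the loss of the trifluoromethoxy group. From the compounds shown here alone, it also remains open whether the chloro on an aromatic carbon has the same effect in a compound carrying benzyl on this oxygen.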